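The source may report more compounds than this note shows. Statements on the series, on what has been measured and on what is new or still open speak of the compounds shown alone.

Of the compounds shown here, three have so far been tested in a functional assay for inhibition, with Homo sapiens as the target; on this read-out higher numbers stand for weaker inhibition and lower numbers for stronger inhibition. Compound 1, with the structure `CCOC(=O)Cn1ncc2cncn2c1=O`, gives in this assay only a limit of > 48000 nM, which is not a number but the edge of what the test can report. Compound 2, with the structure `C=CCSc1nncc2cnc(C)n12`, gives 61000 nM in this assay. Compound 3, with the structure `Cc1cnc(Nc2cc[nH]n2)n2c(C)nc(C)c12`, also returns only a limit in this assay, namely > 48000 nM. Compound 1 therefore stands at a limit rather than at a measured point, and it shares this with compound 3: the limit of > 48000 nM in this assay, at which 2 of the 3 values shown sit. Among the measured compounds shown here, compound 2 is the only one with a true number, and that number stands for weak inhibition.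

The new compound 4 has the structure `CCOC(=O)Cn1ncc2c(C)ncn2c1=O`. It differs from compound 1 by methyl in place of hydrogen on an aromatic carbon of the shared core. For the measured compounds named here, no pair of measured compounds differs in a single place, so there is no measured step to lean on. With compound 1 and compound 3 both at a limit and compound 2 weak, a methyl is expected to leave the picture essentially unchanged. The expected step is a step that the limit leaves unreadable from compound 1 to compound 4, nothing beyond the usual scatter. Compound 4 is therefore expected to give about 60000 nM, within a range from 25000 nM to 150000 nM, and most likely this assay will again report only a limit.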

Compound 4, half-maximal inhibitory concentration: > 48000 nM
Compound 4: no number, only a limit; the forecaster's own chance of this, stated with the estimate: 70%; the middle value lies beyond the limit too.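

No step can be read from compound 1 to compound 4, because each of them gives only a limit and not a number: the limit of > 48000 nM in this assay, at which 3 of the 4 values shown sit.

The compounds shown leave open whether methyl in place of hydrogen on an aromatic carbon of the shared core changes inhibition at all, and how strongly either compound inhibits in this assay.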